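The compounds below may be only part of what the source reports. "The series", "measured", "known", "first", "only" and "open" are said of these compounds alone.

Measured so far in a functional assay on HFF cells (Homo sapiens) for cytotoxicity; on this read-out lower numbers stand for higher toxicity in this test and higher numbers for lower toxicity in this test:
compound 1 `CCCSc1nc(N)nc2c1ncn2/C=C1/C[C@@H]1CO` gives 283000 nM
compound 2 `C#CCNc1nc(N)nc2c1ncn2/C=C1/C[C@@H]1CO` gives 306000 nM
compound 3 `Nc1nc(NC2CC2)c2ncn(/C=C3/C[C@@H]3CO)c2n1` gives 213000 nM

Compound 3 stands level with the other two in this assay since the measured steps to it are a 1.3-fold lower number from compound 1 to compound 3 (0.12 log units; within the scatter) and a 1.4-fold lower number from compound 2 to compound 3 (0.16 log units; within the scatter) and neither leaves the scatter of repeated measurements.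

The next compound to be tested is compound 4 `C=CCNc1nc(N)nc2c1ncn2/C=C1/C[C@@H]1CO` and its difference from compound 3 is allyl in place of cyclopropyl on a nitrogen on an aromatic ring which in words means allyl in place of cyclopropyl on a nitrogen on an aromatic ring. This exact exchange has not been measured. The closest evidence is the change on that same nitrogen, a 1.4-fold lower number from compound 2 to compound 3 (0.16 log units; within the scatter) for cyclopropyl in place of propargyl. Less directly, the exchange of propargylamino for propylsulfanyl on an aromatic carbon gave a 1.1-fold higher number from compound 1 to compound 2 (0.03 log units; within the scatter) and stayed within the scatter as well. Among these three compounds, then, no change at this place has moved the read-out beyond the scatter, and none goes against that. On this evidence the expected step is a 1.2-fold higher number from compound 3 to compound 4 (0.07 log units; within the scatter) with no shift beyond the scatter expected in either direction. The expected value for compound 4 in this assay is 250000 nM with an estimated range from 165000 nM to 380000 nM for now.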

Compound 4, half-maximal cytotoxic concentration: > 368000 nM
Compound 4: only a limit was reported (the forecaster's own chance of this, stated with the estimate: 5%); middle value at least 1.4-fold (0.16 log units) from the limit.
By their numbers in this assay, from the lowest: compounds 3, 1 and 2 (each within the scatter of the next). At a limit, above all of these: compound 4.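

In this assay compound 4 is reported only as a limit, the first such result at this nitrogen: the limit of > 368000 nM in this assay, at which 1 of the 4 values shown sits. Three steps now lead to it, an at least 1.7-fold higher number from compound 3 to compound 4 (0.23 log units; that floor lies within the scatter) and an at least 1.2-fold higher number from compound 2 to compound 4 (0.08 log units; that floor lies within the scatter) and an at least 1.3-fold higher number from compound 1 to compound 4 (0.11 log units; that floor lies within the scatter), and all three are floors that do not by themselves leave the scatter of repeated measurements. For the compounds shown here, what the earlier compounds did not show is that an open allyl chain with its one double bond, taking the place of the cyclopropyl ring or of the propargyl chain on this nitrogen, gives a read-out with no closed upper end, while the three closed numbers stay level with one another.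

From the compounds shown here alone, how far compound 4 truly lies from compound 1, compound 2 and compound 3 cannot be read from a floor, so it remains open whether allyl differs from cyclopropyl here at all. Also open, going by these compounds, is how a longer chain such as butyl, a benzyl group or a dimethylamino group in place of the allylamino group would read in this assay on the same core.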